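A few compounds are considered here, and "the series" means these few. Any claim that something is new, unique, unknown or untested is made for them only; others in the source may bear on it.

Measured so far in a functional assay on FM3A cells (Mus musculus) for antiproliferative activity, read by cell counting, with a stated time of 2 days; on this read-out lower numbers stand for stronger inhibition and higher numbers for weaker inhibition:

compound 1 `COc1cc(C(=O)c2sc(N3CCCC3)nc2N)cc(OC)c1OC` gives 180 nM
compound 2 `COc1ccc(C(=O)c2sc(N3CCCC3)nc2N)cc1OC` gives 112000 nM
compound 3 `COc1ccccc1C(=O)c1sc(N2CCCC2)nc1N` gives > 200000 nM (a limit, not a number)

Compound 3 stands at the limit of > 200000 nM in this assay, at which 1 of the 3 values shown sits, and so has no number of its own. Compound 4 `Nc1nc(N2CCCC2)sc1C(=O)c1ccccc1` differs from it by hydrogen in place of methoxy on an aromatic carbon, ortho to a large group (hydrogen in place of methoxy on an aromatic carbon). One measured step is the same kind of replacement: a 620-fold higher number from compound 1 to compound 2 (2.79 log units; beyond the scatter) is large and goes toward weaker inhibition. The same direction is expected here, but from a limit any further loss in this assay would hardly show as a number. The estimated result is a number no higher from compound 3 to compound 4 (the limit leaves the size open) and should be read as no clear change from that limit. Compound 4 is expected at 200000 nM, within an estimated range of 70000 nM to 400000 nM.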

Compound 4, half-maximal inhibitory concentration: > 200000 nM
Compound 4 gave a limit, no number; the forecaster's own chance of this, stated with the estimate: 60%; the middle value lies on the limit itself.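

The step from compound 3 to compound 4 cannot be read, since each gives a limit and not a number: the limit of > 200000 nM in this assay, at which 2 of the 4 values shown sit. The compounds shown leave open whether replacing this methoxy with hydrogen changes inhibition at all.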